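Fluorine position on the benzyl arm of compound 1

The source may report more compounds than this note shows. Statements on the series, on what has been measured and on what is new or still open speak of the compounds shown alone.

Compound 1 `Nc1cccc(/C=C2\SC(=O)N(Cc3cccc(F)c3)C2=O)c1` carries a 3-fluorophenyl on the saturated chain carbon bound to the amide-type nitrogen of its core. In a functional assay on FM3A cells (Mus musculus) for cytotoxicity, read by cell counting, with a stated time of 2 days (a higher number here means a weaker inhibitor, a lower number a stronger inhibitor), compound 1 returns only a limit, > 250000 nM. Compound 1 thus stands at the limit of > 250000 nM in this assay, at which 1 of the 2 values shown sits. Its companion compound 2 `Nc1ccc(/C=C2\SC(=O)N(Cc3cccc(F)c3)C2=O)cc1` gives 121000 nM in this assay. Placing 4-aminophenyl in place of 3-aminophenyl produced an at least 2.0-fold lower number from compound 1 to compound 2 (0.31 log units; beyond the scatter). That step, however, concerns the aminophenyl side of the core. The unmeasured compound 3 `Nc1cccc(/C=C2\SC(=O)N(Cc3ccc(F)cc3)C2=O)c1` alters the other side: 4-fluorophenyl in place of 3-fluorophenyl on a saturated chain carbon bound to an amide-type nitrogen in a ring. Among the compounds with values here, no measured step touches this position, so the two measured values give no guide to the direction or size of the change. Compound 3 is therefore expected to give 300000 nM in this assay, between 100000 nM and 1000000 nM. That estimate means a step that the limit leaves unreadable from compound 1 to compound 3, expected to fall within the scatter.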

Compound 3, half-maximal inhibitory concentration: 140000 nM
For compound 3 the middle estimate is 2.1-fold (0.33 log units) above the measured one; measured number inside the range.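

Placing 4-fluorophenyl in place of 3-fluorophenyl on the saturated chain carbon bound to the amide-type nitrogen gives the first reading at this position: in this assay, the change produces an at least 1.7-fold lower number from compound 1 to compound 3 (0.25 log units; that floor lies within the scatter). With the 4-fluorophenyl in place, compound 3 returns a measured number, 140000 nM, so this side of the core now has a firm value to compare against. The value of compound 1 is only a limit, so the step has a floor and no true size, and that floor does not clear the scatter: the limit of > 250000 nM in this assay, at which 1 of the 3 values shown sits.

The compounds shown leave open how a chlorine or a methoxy group would read in place of the fluorine on this benzyl arm. They also leave open whether the 4-fluorophenyl and the 4-aminophenyl together, on one core, would give a lower number in this assay than either change alone.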